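Benzofuran for Furan on the Nucleoside Core

The source may hold more compounds than are shown below. What is called first, only, known or untested is meant among the compounds shown, and "the series" means these compounds.

Measured compounds in a functional assay on CCRF-CEM cells (Homo sapiens), read by MTT assay, with a stated time of 72 h; a lower number here means a stronger inhibitor, a higher number a weaker inhibitor:
compound 1 `O=c1[nH]cnc2c1c(-c1ccoc1)cn2[C@@H]1O[C@H](CO)[C@@H](O)[C@H]1O`: 9030 nM
compound 2 `Nc1nc2c(c(-c3ccoc3)cn2[C@@H]2O[C@H](CO)[C@@H](O)[C@H]2O)c(=O)[nH]1`: 17900 nM

In this assay, going by the values given here, compound 1 and compound 2 sit within the scatter of each other, the sole step being a 2.0-fold higher number from compound 1 to compound 2 (0.30 log units; within the scatter). Compound 3 `O=c1[nH]cnc2c1c(-c1cc3ccccc3o1)cn2[C@@H]1O[C@H](CO)[C@@H](O)[C@H]1O` differs from compound 1 by 1-benzofuran-2-yl in place of furan-3-yl on an aromatic carbon. Among the compounds with values here, no measured step touches this change; the one step known concerns an amino group, not the furan, so it gives no direction. On that basis compound 3 is expected to stay close to compound 1, with an expected step of a 1.0-fold lower number from compound 1 to compound 3 (0.00 log units; within the scatter). Compound 3 is estimated at 9000 nM, within a range of 3000 nM to 27000 nM.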

Compound 3, half-maximal inhibitory concentration: > 20000 nM
Compound 3 ended at the assay's limit; the forecaster's own chance of this, stated with the estimate: 15%; at least 2.2-fold (0.34 log units) between middle value and limit.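

In this assay the aromatic carbon that carries furan-3-yl in compound 1 responds to the group placed on it: 1-benzofuran-2-yl gives an at least 2.2-fold higher number from compound 1 to compound 3 (0.34 log units; beyond the scatter). The earlier step concerned an amino group and lay within the scatter, whereas this first step at this position lies beyond it. The value of compound 3 is a limit and not a number: the limit of > 20000 nM in this assay, at which 1 of the 3 values shown sits.

Going by these compounds, it remains open how a methyl group or an aminomethyl group would read on this carbon. On these data alone, it is also open whether furan-2-yl would stay close to compound 1 or move towards compound 3.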